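The compounds below may be only part of what the source reports. "The series", "measured", "known", "first", "only" and "open" are said of these compounds alone.

Among the compounds with values here, the three compounds measured so far share the core of compound 1, `CC1=CC[C@H](C(C)(C)N=C=S)CC1`. In a functional assay on OVCAR-3 cells (Homo sapiens) for inhibition, read by sulforhodamine B assay, with a stated time of 48 h (a higher number here means a weaker inhibitor of growth, a lower number a stronger inhibitor of growth), compound 1 gives > 100000 nM; this is a limit of the assay, not a number. Compound 2, `CC1=CC[C@H](C(C)(C)NC(=S)N/N=C/c2ccc(O)cc2)CC1`, extends that core with an arm that ends in a 4-hydroxyphenyl group. In this assay compound 2 gives > 100000 nM, again only a limit. Compound 3, `CC1=CC[C@H](C(C)(C)NC(=S)N/N=C/c2ccc(N(C)C)cc2)CC1`, differs from compound 2 in one place, with dimethylamino in place of hydroxy on an aromatic carbon. In this assay compound 3 gives > 100000 nM, also a limit. The resulting step is a step that the two limits leave unreadable from compound 2 to compound 3. Compound 2 therefore stands at the limit of > 100000 nM in this assay, at which 3 of the 3 values shown sit, and nothing in the measured values separates it from compound 1 or compound 3.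

Compound 4, `CC1=CC[C@H](C(C)(C)NC(=S)N/N=C/c2cccc(Cl)c2)CC1`, is the next compound. It differs from compound 2 by 3-chlorophenyl in place of 4-hydroxyphenyl on a carbon with a double bond to nitrogen. Within the data shown here, the only measured step at this position is the one from compound 2 to compound 3, and it carries no readable size, so no measured step points in either direction here. The step that the estimate below means, a number no higher from compound 2 to compound 4 (the limit leaves the size open), is expected to be no movement beyond the scatter, with another limit the most likely outcome. Compound 4 is expected to give about 100000 nM in this assay, within a range from 30000 nM to 300000 nM.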

Compound 4, concentration for total growth inhibition: 80500 nM
Beside the measured number, compound 4's estimate is 1.2-fold (0.09 log units) above it, and the stated range covers the measured number.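

In this assay, within the data shown here, compound 4 is the first compound here to give a real number, 80500 nM, rather than a limit of the assay, so this position can at least bring a reading inside the measurable range. The change to 3-chlorophenyl, which has no hydrogen-bond donor or acceptor where 4-hydroxyphenyl has one of each, gives an at least 1.2-fold lower number from compound 2 to compound 4 (0.09 log units; that floor lies within the scatter). That figure is only a floor, and the true size of the step stays unknown, since compound 2 has no number of its own: the limit of > 100000 nM in this assay, at which 3 of the 4 values shown sit.

The compounds shown leave open whether the chlorine matters at all, or whether the change from 4-hydroxyphenyl is what counts, since only this one arm gives a number. From the compounds shown here alone, how a plain phenyl, or a ring carrying a nitrile or a carboxylic acid in place of the chlorine, would read in this assay also remains open.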